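The compounds below may be only part of what the source reports. "The series", "measured", "known", "first", "only" and "open" are said of these compounds alone.

Measured so far in a functional assay on HeLa cells (Homo sapiens) for inhibition, read by sulforhodamine B assay; on this read-out higher numbers stand for weaker inhibition and lower numbers for stronger inhibition:

compound 1 `O=C1C(Nc2ccc(Br)cc2)=CC(=O)c2c1nc1n2[C@H]2OC[C@@H](O)[C@H]2OC1`, which gives 5220 nM;
compound 3 `Cc1ccc(NC2=CC(=O)c3nc4n(c3C2=O)[C@H]2OC[C@@H](O)[C@H]2OC4)cc1C`, which gives 2690 nM;
compound 2 `O=C1C=C(NC2CCCC2)C(=O)c2c1nc1n2[C@H]2OC[C@@H](O)[C@H]2OC1`, for which the measurement stopped at a limit of the assay and gave no number: > 16000 nM.

Of the two numbers, that of compound 1 is the higher, but compound 3 sits close enough that the gap lies within the usual scatter, so the two cannot be told apart.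

Compound 4 `CCOc1ccccc1NC1=CC(=O)c2c(nc3n2[C@H]2OC[C@@H](O)[C@H]2OC3)C1=O` differs from compound 1 in a single place: 2-ethoxyphenyl in place of 4-bromophenyl on an amine nitrogen. Going by the values given here, only one measured step exists, an at least 5.9-fold lower number from compound 2 to compound 3 (0.77 log units; beyond the scatter), and it concerns a cyclopentyl giving way to an aromatic group, not one aromatic group giving way to another. Compounds 1 and 3 do carry two different aromatic groups on that nitrogen, and their values fall within the scatter of each other. On this basis no step beyond the scatter is expected in this assay: a 1.3-fold lower number from compound 1 to compound 4 (0.12 log units; within the scatter). Compound 4 is therefore estimated at 4000 nM, within a range from 1500 nM to 12000 nM.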

Compound 4, half-maximal inhibitory concentration: 8300 nM
Estimate against measurement, compound 4: 2.1-fold (0.32 log units) below; measured number inside the range.
By their numbers in this assay, from the lowest: compounds 3, 1 and 4 (each within the scatter of the next, the first and the last beyond it). At a limit, above all of these: compound 2.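

In this assay, putting 2-ethoxyphenyl in place of 4-bromophenyl on the amine nitrogen gives a 1.6-fold higher number from compound 1 to compound 4 (0.20 log units; within the scatter), so this swap cannot be told apart from no change. At this position, then, a larger aromatic group that has lost the bromine and gained an oxygen, a hydrogen-bond acceptor, leaves the reading where it was, within the scatter. None of the data shown offers a reason for this result.

This swap changes both the group on the ring and where the name places it. 4-ethoxyphenyl and 2-bromophenyl would be needed to separate those two changes. It also remains open how this assay would respond to a phenyl ring carrying a carboxylic acid or an amine, groups absent from the compounds shown.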